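The source may hold more compounds than are shown below. What is called first, only, known or untested is meant among the compounds shown, and "the series" means these compounds.

In a functional assay on HL-60 cells (Homo sapiens) for cytotoxicity, read by WST assay, with a stated time of 48 h (a lower number here means that less compound is needed, a higher number that more compound is needed for the effect), compound 1 `O=C1OC[C@H](Cc2ccccc2)[C@H]1Cc1ccccc1OC(F)(F)F` gives 39000 nM, within the scatter of both its measured relatives: compound 2 `COCOc1ccccc1C[C@H]1C(=O)OC[C@@H]1Cc1ccccc1` gives 76000 nM and compound 3 `CCCCOc1ccccc1C[C@H]1C(=O)OC[C@@H]1Cc1ccccc1` gives 20000 nM. The change to compound 4 `O=C1OC[C@H](Cc2ccccc2)[C@H]1Cc1ccccc1C(F)(F)F` is trifluoromethyl in place of trifluoromethoxy on an aromatic carbon. The measured steps only alter what sits on the oxygen. Two stay within the scatter, a 1.9-fold higher number from compound 1 to compound 2 (0.29 log units; within the scatter) and a 2.0-fold lower number from compound 1 to compound 3 (0.29 log units; within the scatter), while a 3.8-fold lower number from compound 2 to compound 3 (0.58 log units; beyond the scatter) is a modest step beyond it. None removes that oxygen, so they bear only indirectly on compound 4. No step beyond the scatter is expected in this assay, and the estimated step is a 1.1-fold lower number from compound 1 to compound 4 (0.05 log units; within the scatter). Compound 4 is estimated at 35000 nM, with an expected range of 15000 nM to 80000 nM.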

Compound 4, half-maximal effective concentration: 37000 nM
Compound 4: the middle estimate sits 1.1-fold (0.02 log units) below what was measured, within the range that was stated.
By their numbers in this assay, from the lowest: compounds 3, 4, 1 and 2 (each within the scatter of the next, the first and the last beyond it).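

In this assay, the oxygen itself proves dispensable at this aromatic carbon: trifluoromethyl in place of trifluoromethoxy gives a 1.1-fold lower number from compound 1 to compound 4 (0.02 log units; within the scatter). Against the other oxygen-linked groups, butoxy gives a 1.9-fold higher number from compound 3 to compound 4 (0.27 log units; within the scatter), whereas methoxymethoxy gives a 2.1-fold lower number from compound 2 to compound 4 (0.31 log units; beyond the scatter), a modest step. Nothing shown explains these results.

The compounds shown leave open whether a group with a different kind of atom at this place, such as an amine or a carboxylic acid, would stay within this narrow span. They also leave open how a chain longer than butoxy would behave.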